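Chloro for Methoxy on a Shared Quinoline-Ether Core

The compounds below may be only part of what the source reports. "The series", "measured", "known", "first", "only" and "open" are said of these compounds alone.

Measured compounds:
compound 1 `COc1ccc(Oc2ccc3c(NCCCNCc4cc(F)ccc4OC)ccnc3c2)cc1` — 7000 nM
compound 2 `COc1ccc(Oc2ccc3c(NCCCNCc4ccco4)ccnc3c2)cc1` — 5300 nM

In an ADME assay on HepG2 cells (Homo sapiens) for cytotoxicity, read by luminescence, CellTiter-Glo and ATP content, with a stated time of 72 h (a lower number here means that less compound is needed, a higher number that more compound is needed for the effect), compound 1 gives 7000 nM, and compound 2 gives 5300 nM; the two sit within the scatter of each other, as the step of a 1.3-fold lower number from compound 1 to compound 2 (0.12 log units; within the scatter) shows. Compound 3 `COc1ccc(F)cc1CNCCCNc1ccnc2cc(Oc3ccc(Cl)cc3)ccc12` differs from compound 1 by chloro in place of methoxy on an aromatic carbon. Within the data shown here, the only measured step concerns the other end of the molecule and does not touch this position, so nothing measured bears directly on the change. Compound 3 is therefore expected to give about 7000 nM, between 3000 nM and 16000 nM, a step of no change at the digits printed from compound 1 to compound 3 (within the scatter) that is expected to stay within the scatter.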

Compound 3, half-maximal effective concentration: 4500 nM
For compound 3 the middle estimate is 1.6-fold (0.19 log units) above the measured one, and the stated range covers the measured number.
By their numbers in this assay, from the lowest: compounds 3, 2 and 1 (each within the scatter of the next).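

In this assay, among these compounds, the position on the 4-methoxyphenoxy end is now measured for the first time, and the result is a 1.6-fold lower number from compound 1 to compound 3 (0.19 log units; within the scatter). Chloro in place of methoxy on this aromatic carbon therefore leaves the two compounds within the scatter of each other, even though one hydrogen-bond acceptor is lost. Nothing available explains this result.

Going by these compounds, it stays open whether an amine or a carboxylic acid at this position would also stay within the scatter. On these data alone, it also stays open whether chloro would behave the same way alongside the furan-2-yl end of compound 2.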